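The source may hold more compounds than are shown below. What is called first, only, known or untested is meant among the compounds shown, and "the series" means these compounds.

Measured so far, in a functional assay on A-431 cells (Homo sapiens) for inhibition, read by MTT assay, with a stated time of 72 h; on this read-out lower numbers stand for stronger inhibition and higher numbers for weaker inhibition:
- compound 1 `c1ccc(-c2nnc(SCCCN3CCN(c4nc5ccccc5o4)CC3)o2)cc1` gives 57600 nM
- compound 2 `O=C(NCc1nnc(SCCCN2CCN(c3nc4ccccc4o3)CC2)o1)c1ccccc1` gives 36900 nM
- compound 3 `c1ccc(-c2nnc(SCCCN3CCN(c4nc5ccccc5s4)CC3)o2)cc1` gives 93400 nM

Compound 2 differs from compound 1 in one place: benzamidomethyl in place of phenyl on an aromatic carbon. That change made a 1.6-fold lower number from compound 1 to compound 2 (0.19 log units; within the scatter). Compound 3 differs from compound 1 at another place: 1,3-benzothiazol-2-yl in place of 1,3-benzoxazol-2-yl on an amine nitrogen in a ring. That change made a 1.6-fold higher number from compound 1 to compound 3 (0.21 log units; within the scatter). Compound 2 and compound 3 differ in both places at once; their two numbers are further apart, beyond the usual scatter, with compound 3 giving the higher one.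

Compound 4 `O=C(NCc1nnc(SCCCN2CCN(c3nc4ccccc4s3)CC2)o1)c1ccccc1` has not yet been measured in this assay. It carries the core of compound 3 and differs from it in one place: benzamidomethyl in place of phenyl on an aromatic carbon. This is the same change that turned compound 1 into compound 2, made on the other core; the place is described in the same words for both.

For compound 4, the step expected is a 1.6-fold lower number from compound 3 to compound 4 (0.21 log units; within the scatter). Among the measured compounds shown here, that expected step is taken to be of about the same size as the one measured from compound 1 to compound 2, which rests on that single measured pair, because a 1.6-fold lower number from compound 1 to compound 2 (0.19 log units; within the scatter) lay within the scatter. Compound 4 is therefore estimated to give about 58000 nM in this assay, somewhere between 25000 nM and 140000 nM.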

Compound 4, half-maximal inhibitory concentration: 55900 nM
Beside the measured number, compound 4's estimate is 1.0-fold (0.02 log units) above it; the measured number falls inside the stated range.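

In this assay, putting benzamidomethyl in place of phenyl gave a 1.7-fold lower number from compound 3 to compound 4 (0.22 log units; within the scatter), a step that closely matches the one seen on the other core: the same change on two cores in this assay, a 1.6-fold lower number (0.19 log units; within the scatter) from compound 1 to compound 2 and a 1.7-fold lower number (0.22 log units; within the scatter) from compound 3 to compound 4, 1.1-fold (0.03 log units) apart, within the scatter of two such steps
Putting 1,3-benzothiazol-2-yl in place of 1,3-benzoxazol-2-yl gave a 1.5-fold higher number from compound 2 to compound 4 (0.18 log units; within the scatter), and this step also matches its earlier counterpart: the same change on two cores in this assay, a 1.6-fold higher number (0.21 log units; within the scatter) from compound 1 to compound 3 and a 1.5-fold higher number (0.18 log units; within the scatter) from compound 2 to compound 4, 1.1-fold (0.03 log units) apart, within the scatter of two such steps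
So across these four compounds, each change carried over from one core to the other at about the same size, but every step lies within the scatter, and each change rests on only two pairs, so this does not show that either change truly shifts the number or that the match would hold on other cores.

Still open, from the compounds shown here alone, is whether a different group on that aromatic carbon, such as an amine or a carboxylic acid, would move the number beyond the scatter. Also open, going by these compounds, is what a longer chain on the sulfur would do.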